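Acetylation of a Hydroxy Group in a Cytotoxicity Series

The source may hold more compounds than are shown below. What is called first, only, known or untested is meant among the compounds shown, and "the series" means these compounds.

Compound 1, `COc1ccc(C(=O)OCC2=CC[C@@]3(C)CCC(C(C)C)=C3CC2)cc1`, in a functional assay on HeLa cells (Homo sapiens) for cytotoxicity, read by MTT assay, with a stated time of 72 h; on this read-out higher numbers stand for weaker inhibition and lower numbers for stronger inhibition: > 100000 nM, a limit of the assay rather than a number.
Compound 2, `COc1ccc(C(=O)O[C@H]2CC(C)=C[C@H](O)[C@@]3(C)[C@@H](OC(C)=O)C[C@@](O)(C(C)C)[C@H]23)cc1`, in this assay: 52900 nM.

Among the measured compounds shown here, compound 2 supplies the only number in this assay; the other value shown is a limit, the one recorded for compound 1 (the limit of > 100000 nM in this assay, at which 1 of the 2 values shown sits). For the measured compounds named here, no two measured compounds differ in a single place, so there is no measured step to calibrate the change leading to compound 3, `COc1ccc(C(=O)O[C@H]2CC(C)=C[C@H](OC(C)=O)[C@@]3(C)[C@@H](OC(C)=O)C[C@@](O)(C(C)C)[C@H]23)cc1`. Compound 3 differs from compound 2 by acetyl in place of hydrogen on an oxygen on a saturated carbon. Going by the values given here, with no measured step to lean on, this change is expected to give only a small shift in this assay, most likely within the scatter of the assay, and its direction stays open. The expected step is a 1.2-fold lower number from compound 2 to compound 3 (0.07 log units; within the scatter). Compound 3 is estimated at 45000 nM in this assay, with a range from 15000 nM to 100000 nM. This estimate is anchored on compound 2 because it gives 52900 nM. For compound 3, a result that is reported only as a limit of the assay cannot be ruled out.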

Compound 3, half-maximal inhibitory concentration: 14500 nM
For compound 3 the middle estimate is 3.1-fold (0.49 log units) above the measured one, outside the stated range (below it).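

Turning hydroxy to acetoxy, on an oxygen on a saturated carbon whose other neighbours are saturated ring carbon, gives in this assay a 3.6-fold lower number from compound 2 to compound 3 (0.56 log units; beyond the scatter) and is the only step in the series that can be read. It shows that this position is sensitive to what is placed on its oxygen, and that the change runs towards stronger inhibition on this read-out. It also shows that the hydrogen on this oxygen is not needed for compound 3 to retain a measurable value, though the data give no measured reason for the step.

Whether the shift belongs to acetyl itself or would follow from any replacement of that hydrogen stays open, since the compounds shown include no methyl ether, no longer ester such as propanoyl and no benzoyl ester on this oxygen. Also open, going by these compounds, is whether the remaining hydroxy on the shared core would respond in the same direction if it carried an acetyl group, as this single step speaks for one position only.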